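The source may hold more compounds than are shown below. What is called first, only, known or untested is meant among the compounds shown, and "the series" means these compounds.

Working notes on the series. Compound 1 `O=C(CN(c1nc(Cl)nc2[nH]cnc12)C1CC1)N[C@@H](CO)C(=O)OCc1ccccc1` and compound 2 `C[C@@H](O)[C@H](NC(=O)CN(c1nc(Cl)nc2[nH]cnc12)C1CC1)C(=O)OCc1ccccc1` share the same core and the same benzyl ester. In a functional assay on the whole organism (Tail, strain ICR) with Mus musculus as the target, in the tail flick test, with a stated time of 90 min, at a dose of 25 umol/kg by the oral route (a lower number here means a weaker effect, a higher number a stronger effect of the compound at the dose given), compound 1 gives 34.5%, and in this assay compound 2 gives 29.9%. Among the compounds with values here, the single step measured, a number 4.6 percentage points lower from compound 1 to compound 2 (within the scatter), places compound 2 at the lower of the two numbers, with compound 1 nearest and within the scatter, so no order between them can be read.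

Compound 3 `O=C(CN(c1nc(Cl)nc2[nH]cnc12)C1CC1)N[C@@H](CCC(=O)OCc1ccccc1)C(=O)OCc1ccccc1` is the next member, differing from compound 2 by 2-(benzyloxycarbonyl)ethyl in place of 1-hydroxyethyl on a saturated chain carbon bound to an amide-type nitrogen and a carbonyl carbon. Within the data shown here, no measured step bears directly on this change: the one step known, a number 4.6 percentage points lower from compound 1 to compound 2 (within the scatter), concerns a different substitution and stays within the scatter, so it gives no direction for a much larger replacement. The step of a number 1.9 percentage points lower from compound 2 to compound 3 (within the scatter) is therefore expected to be small, with a wide range either way. For compound 3 the estimate is 28%, between 8% and 50%.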

Compound 3, a percentage reported as activity, at one dose (the size of the read-out at that dose, not a potency): 50%
Estimate against measurement, compound 3: 22 percentage points below; the range from low to high includes it.
By their numbers in this assay, from the lowest: compounds 2 and 1 (each within the scatter of the next); then compound 3.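

At the saturated chain carbon bound to an amide-type nitrogen and a carbonyl carbon, a change now reads beyond the scatter in this assay: 2-(benzyloxycarbonyl)ethyl in place of 1-hydroxyethyl gives a number 20.1 percentage points higher from compound 2 to compound 3 (beyond the scatter). The comparison with the hydroxy compound points the same way, with (benzyloxycarbonyl)methyl in place of hydroxy giving a number 15.5 percentage points higher from compound 1 to compound 3 (beyond the scatter), so this replacement separates compounds where the methyl step alone did not. Nothing available gives a cause for either step.

The compounds shown leave open whether the higher number follows the added benzyl ester or the longer chain alone. A free carboxylic acid in place of that ester, or a plain propyl chain at the same place, would separate these two readings.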